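Swapping Carbamoyl for Trifluoromethyl: a Second Test

A few compounds are considered here, and "the series" means these few. Any claim that something is new, unique, unknown or untested is made for them only; others in the source may bear on it.

Compound 1 `O=c1ccc(-c2ccc3cn[nH]c3c2)cn1Cc1ccccc1C(F)(F)F`: in an assay for inhibition of MAP kinase-interacting serine/threonine-protein kinase 2 (Homo sapiens), read by luminescence and ADP-Glo, with a stated time of 2 h (a higher number here means a weaker inhibitor, a lower number a stronger inhibitor), compound 1 gives 100 nM.
Compound 2 `NC(=O)c1ccccc1Cn1cc(-c2ccc3cn[nH]c3c2)ccc1=O`: in this assay compound 2 gives 340 nM.
Compound 3 `NC(=O)c1ccc(Cn2cc(-c3ccc4cn[nH]c4c3)ccc2=O)cc1`: in this assay compound 3 gives only a limit, > 2000 nM.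

Compound 3 sits at the limit of > 2000 nM in this assay, at which 1 of the 3 values shown sits, so its potency is known only as a limit, not a number. Compound 4 `O=c1ccc(-c2ccc3cn[nH]c3c2)cn1Cc1ccc(C(F)(F)F)cc1` is not yet measured. It differs from compound 3 by trifluoromethyl in place of carbamoyl on an aromatic carbon. The same kind of change has been made once before, from compound 2 to compound 1: trifluoromethyl in place of carbamoyl on an aromatic carbon, where the new group sits ortho to a large group rather than para to a large group, and that step gave a 3.4-fold lower number from compound 2 to compound 1 (0.53 log units; beyond the scatter). The difference between the core of compound 2 and that of compound 3 is not broken down here. Because compound 3 is known only as a limit, the step to compound 4 cannot be pinned down, but a step in the same direction is expected, a step that the limit leaves unreadable from compound 3 to compound 4, resting on a 3.4-fold lower number from compound 2 to compound 1 (0.53 log units; beyond the scatter). Compound 4 is therefore estimated at about 2500 nM in this assay, within 600 nM to 10000 nM.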

Compound 4, half-maximal inhibitory concentration: 1110 nM
The estimate for compound 4 lay 2.3-fold (0.35 log units) above the measured number, and the stated range covers the measured number.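

In this assay, trifluoromethyl in place of carbamoyl gives an at least 1.8-fold lower number from compound 3 to compound 4 (0.25 log units; that floor lies within the scatter), so only a floor for this step is known, and that floor alone does not establish a real change. Compound 3 gives > 2000 nM, which is a limit and not a number. The change may carry over from one core to the other, but neither its size nor a firm direction on this second core can be claimed, and the comparison stays unsettled: the same change on two cores in this assay, a 3.4-fold lower number (0.53 log units; beyond the scatter) from compound 2 to compound 1 and an at least 1.8-fold lower number (0.25 log units; that floor lies within the scatter) from compound 3 to compound 4; the limit leaves it open whether they differ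

The compounds shown leave open how a nitrile, a carboxylic acid or an amine would behave in the place of these two groups. They also leave open whether the step would hold at any other place on that ring.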